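From amide to sulfonamide: expecting compound 4's cytotoxicity

The source may hold more compounds than are shown below. What is called first, only, known or untested is meant among the compounds shown, and "the series" means these compounds.

Compound 1 `O=C(NCCNc1nccc(-c2c(-c3cccc(F)c3)nc3sccn23)n1)c1c(F)cccc1F` has the lowest of the three numbers measured in a functional assay on A-375 cells (Homo sapiens) for cytotoxicity, read by MTT assay (on this read-out lower numbers stand for stronger inhibition and higher numbers for weaker inhibition), giving 2700 nM. Compound 3 `O=S(=O)(NCCCNc1nccc(-c2c(-c3cccc(F)c3)nc3sccn23)n1)c1ccc(C(F)(F)F)cc1` gives 4090 nM, a value within the scatter of compound 1, while compound 2 `COc1ccc(S(=O)(=O)NCCCNc2nccc(-c3c(-c4cccc(F)c4)nc4sccn34)n2)cc1` gives 5510 nM, beyond it. Compound 4 `Cc1ccc(S(=O)(=O)NCCNc2nccc(-c3c(-c4cccc(F)c4)nc4sccn34)n2)cc1` carries (4-methylphenyl)sulfonyl in place of (2,6-difluorophenyl)carbonyl on an amine nitrogen. For the measured compounds named here, the only measured one-place step among the sulfonamides, a 1.3-fold lower number from compound 2 to compound 3 (0.13 log units; within the scatter), shows that the group on that aryl ring barely matters. Going by the values given here, compounds 2 and 3 differ from compound 1 in more than this one place, so no measured step isolates the amide-to-sulfonamide exchange itself. Compound 4 is therefore expected to fall near the sulfonamides, a 1.5-fold higher number from compound 1 to compound 4 (0.17 log units; within the scatter), with an estimate of 4000 nM and a range of 1500 nM to 10000 nM.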

Compound 4, half-maximal inhibitory concentration: 15400 nM
Beside the measured number, compound 4's estimate is 3.9-fold (0.59 log units) below it; measured number outside the range, above it.
By their numbers in this assay, from the lowest: compounds 1, 3 and 2 (each within the scatter of the next, the first and the last beyond it); then compound 4.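

In this assay, for the compounds shown here, this is the first measured one-place step that sets a sulfonyl-linked group against a carbonyl-linked group on this amine nitrogen. (4-Methylphenyl)sulfonyl in place of (2,6-difluorophenyl)carbonyl gives a 5.7-fold higher number from compound 1 to compound 4 (0.76 log units; beyond the scatter) and lies beyond the scatter, so this position responds to the change even though both groups have the same heavy-atom count. No measurement available here accounts for this step.

The link and the ring substituents change together, so the compounds shown cannot separate their contributions. A (2,6-difluorophenyl)sulfonyl group or a (4-methylphenyl)carbonyl group on the same chain would pull them apart.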